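Swapping Ethynyl for Furan-3-yl on Two Related Cores

The source may report more compounds than this note shows. Statements on the series, on what has been measured and on what is new or still open speak of the compounds shown alone.

Compound 1 `C#Cc1cn([C@@H]2O[C@H](CO)[C@@H](O)[C@H]2O)c2ncnc(C)c12` is a sugar-linked bicyclic compound carrying an ethynyl group. In an ADME assay on BJ cells (Homo sapiens), read by MTT assay, with a stated time of 72 h (on this read-out lower numbers stand for stronger inhibition and higher numbers for weaker inhibition), compound 1 gives 50 nM. Compound 2 `Cc1ncnc2c1c(-c1ccoc1)cn2[C@@H]1O[C@H](CO)[C@@H](O)[C@H]1O` differs from it in one place: furan-3-yl in place of ethynyl on an aromatic carbon. That change gave a 1800-fold higher number from compound 1 to compound 2 (3.25 log units; beyond the scatter), and in this assay compound 2 gives 89200 nM. Compound 3 `C#Cc1cn([C@@H]2O[C@H](CO)[C@@H](O)[C@H]2O)c2nc(N)nc(OC)c12` keeps the ethynyl group but has a different core; the difference between the two cores is not broken down here. In this assay compound 3 gives > 100000 nM, which is a limit of the assay and not a number. Within the data shown here, compound 4 `COc1nc(N)nc2c1c(-c1ccoc1)cn2[C@@H]1O[C@H](CO)[C@@H](O)[C@H]1O` has not been measured; it differs from compound 3 by furan-3-yl in place of ethynyl on an aromatic carbon, the same change as the one from compound 1 to compound 2, at the same place. Compound 3 already sits at the limit of > 100000 nM in this assay, at which 1 of the 3 values shown sits. Because the same change gave a 1800-fold higher number from compound 1 to compound 2 (3.25 log units; beyond the scatter), compound 4 is expected to remain at or beyond that limit. The expected step is a step that the limit leaves unreadable from compound 3 to compound 4, with the estimate for compound 4 at 150000 nM, between 60000 nM and 1000000 nM.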

Compound 4, half-maximal inhibitory concentration: > 100000 nM
Compound 4: only a limit was reported; the forecaster's own chance of this, stated with the estimate: 90%; the middle value is on the limit's open side.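

Compound 3 and compound 4 both stop at a limit of this assay and not at a number, so the step between them cannot be read: the limit of > 100000 nM in this assay, at which 2 of the 4 values shown sit.

The compounds shown leave open whether furan-3-yl in place of ethynyl shifts the read-out on the core of compound 3 as strongly as on the core of compound 1.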